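Pyrazole ureas: removing the methyl from the aryl methoxy

The source may hold more compounds than are shown below. What is called first, only, known or untested is meant among the compounds shown, and "the series" means these compounds.

Of the compounds shown here, two have numbers so far. Compound 1 `O=C(Nc1cccc(-n2cc(-c3ccncc3)c(-c3ccc(Cl)c(O)c3)n2)c1)Nc1cccc(C(F)(F)F)c1` carries the hydroxy group on its aryl ring and a single trifluoromethyl on the urea phenyl; in a functional assay on MDA-MB-435 cells (Homo sapiens) for inhibition, read by sulforhodamine B assay, with a stated time of 48 h (on this read-out higher numbers stand for lower toxicity in this test and lower numbers for higher toxicity in this test), compound 1 gives only a limit of > 32500 nM, not a number. Within the data shown here, compound 2 `COc1cc(-c2nn(-c3cccc(NC(=O)Nc4cc(C(F)(F)F)cc(C(F)(F)F)c4)c3)cc2-c2ccncc2)ccc1Cl` carries the methoxy group and two trifluoromethyl groups; in this assay compound 2 gives 4460 nM, the only real number in the set. The other entry, that of compound 1, is a limit (the limit of > 32500 nM in this assay, at which 1 of the 2 values shown sits). Among the measured compounds shown here, no step between measured compounds is available, so these two values are simply set side by side.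

Compound 3 `O=C(Nc1cccc(-n2cc(-c3ccncc3)c(-c3ccc(Cl)c(O)c3)n2)c1)Nc1cc(C(F)(F)F)cc(C(F)(F)F)c1` is the next candidate. It differs from compound 2 by hydrogen in place of methyl on an oxygen on an aromatic ring, and keeps the two trifluoromethyl groups. For the measured compounds named here, no measured step covers this change. The expectation is a step from compound 2 to compound 3 of a 2.7-fold higher number from compound 2 to compound 3 (0.43 log units; beyond the scatter) toward weaker toxicity, beyond the scatter, with a real chance that only a limit is returned. For compound 3 the estimate in this assay is 12000 nM, within 3000 nM to 40000 nM.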

Compound 3, concentration lethal to 50% of the cells: 15600 nM
For compound 3 the middle estimate is 1.3-fold (0.11 log units) below the measured one, and the stated range covers the measured number.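

Replacing methyl with hydrogen on the oxygen, methoxy to hydroxy on the aryl ring, now has a direct reading in this assay: with both trifluoromethyl groups kept, the change gives a 3.5-fold higher number from compound 2 to compound 3 (0.54 log units; beyond the scatter), which points toward lower toxicity in this test. The second trifluoromethyl group, in place of hydrogen on an aromatic carbon, gives an at least 2.0-fold lower number from compound 1 to compound 3 (0.31 log units; beyond the scatter) with the hydroxy group held in place, so a hydroxy compound in this series can also return a real number. Compound 1 stands at a limit and not at a number, so this second step gives a bound and not a size: the limit of > 32500 nM in this assay, at which 1 of the 3 values shown sits.

The compounds shown leave open whether the methoxy to hydroxy step keeps its size with a single trifluoromethyl group on the urea phenyl, since both readings here come from the bis-trifluoromethyl pair. They also leave open how an ethoxy group, a longer alkoxy chain or an amine at the same place on the aromatic ring would read in this assay, and whether the number would fall between those of the methoxy and hydroxy compounds.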